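A Furan-3-yl Ring in Place of Phenyl

The compounds below may be only part of what the source reports. "The series", "measured", "known", "first", "only" and "open" are said of these compounds alone.

Compound 2 `CNc1ncnc2c1c(-c1ccccc1)cn2[C@@H]1O[C@H](CO)[C@@H](O)[C@H]1O` carries a phenyl group on the shared core. In an ADME assay on BJ cells (Homo sapiens), read by MTT assay, with a stated time of 72 h (a higher number here means a weaker inhibitor, a lower number a stronger inhibitor), compound 2 gives only a limit, > 100000 nM, one of the shown values sitting at that limit (the limit of > 100000 nM in this assay, at which 1 of the 2 values shown sits). Compound 1 `COc1ncnc2c1c(-c1ccoc1)cn2[C@@H]1O[C@H](CO)[C@@H](O)[C@H]1O` differs from compound 2 in two places; in this assay compound 1 gives 28800 nM. Compound 3 `CNc1ncnc2c1c(-c1ccoc1)cn2[C@@H]1O[C@H](CO)[C@@H](O)[C@H]1O` differs from compound 2 by furan-3-yl in place of phenyl on an aromatic carbon. With no single-change comparison available, the step from compound 2 to compound 3 is expected to be an at least 1.6-fold lower number from compound 2 to compound 3 (0.22 log units; that floor lies within the scatter), toward stronger inhibition but possibly not beyond the scatter. Compound 3 is expected to give about 60000 nM in this assay, within 20000 nM to 200000 nM.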

Compound 3, half-maximal inhibitory concentration: 96300 nM
Compound 3: the middle estimate sits 1.6-fold (0.21 log units) below what was measured; the range from low to high includes it.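

Furan-3-yl in place of phenyl on this aromatic carbon gives an at least 1.0-fold lower number from compound 2 to compound 3 (0.01 log units; that floor lies within the scatter), so no change beyond the scatter can be claimed in this assay. Compound 2 has only a limit, so the true size of this step cannot be read: the limit of > 100000 nM in this assay, at which 1 of the 3 values shown sits.

The clearer step comes from the other change, with furan-3-yl kept: methylamino in place of methoxy gives a 3.3-fold higher number from compound 1 to compound 3 (0.52 log units; beyond the scatter), toward weaker inhibition. Going by these compounds, whether a pyridine ring on this aromatic carbon, or ethylamino in place of methylamino, would shift the number stays open.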